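Series notes: from compound 3 to compound 4

This account rests on a few compounds, and the source may have more. Where it says the series, first, only, none or still open, it means among the compounds named here.

Compound 1 `CC(C)(C)c1ccc(NC(=O)c2ccc(-c3ncccc3C#N)cc2)cc1` gives 30 nM in a functional assay for antagonist activity at transient receptor potential cation channel subfamily V member 1 (Homo sapiens), read by FLIPR; on this read-out higher numbers stand for weaker inhibition and lower numbers for stronger inhibition. Compound 2 `CC(C)(C)c1ccc(NC(=O)c2ccc(-c3ncccc3NC3CCCC3)cc2)cc1` gives 190 nM in this assay; that is a 6.3-fold higher number from compound 1 to compound 2 (0.80 log units; beyond the scatter). For compound 3 `CC(C)(C)c1ccc(NC(=O)c2ccc(-c3ncccc3C(=O)O)cc2)cc1` the reading in this assay is a limit, > 4000 nM. Compound 3 therefore sits at the limit of > 4000 nM in this assay, at which 1 of the 3 values shown sits, the weak end of the measured set. Moving to the carboxy brings an at least 130-fold higher number from compound 1 to compound 3 (2.12 log units; beyond the scatter) and an at least 21-fold higher number from compound 2 to compound 3 (1.32 log units; beyond the scatter). Compound 4 `CC(C)(C)c1ccc(NC(=O)c2ccc(-c3ncccc3C(=N)N)cc2)cc1` changes compound 3 by a group of 3 heavy atoms (1 carbon, 2 nitrogen; no ring) in place of a group of 3 heavy atoms (1 carbon, 2 oxygen; no ring), on an aromatic carbon. Both large steps into compound 3 run toward weaker inhibition, so leaving the carboxy behind is expected to run the other way, without reaching the numbers of compound 1 or compound 2. The expected step is an at least 6.6-fold lower number from compound 3 to compound 4 (0.82 log units; beyond the scatter) in this assay. Compound 4 is estimated at 600 nM, within 100 nM to 4000 nM.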

Compound 4, half-maximal inhibitory concentration: > 4000 nM
Compound 4: a limit, no number (the forecaster's own chance of this, stated with the estimate: 25%); at least 6.6-fold (0.82 log units) between middle value and limit.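

In this assay compound 4 gives > 4000 nM, which is a limit, so a second group on this aromatic carbon now stands at the weak end of the set: the limit of > 4000 nM in this assay, at which 2 of the 4 values shown sit.

The entering group gives an at least 130-fold higher number from compound 1 to compound 4 (2.12 log units; beyond the scatter) and an at least 21-fold higher number from compound 2 to compound 4 (1.32 log units; beyond the scatter). The step between the two limits cannot be read, so compound 3 and compound 4 cannot be ordered.

Open, as far as these compounds go, is whether a primary amide, a methyl ester or a primary amine at this position would give a reading clear of the limit.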